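This account rests on a few compounds, and the source may have more. Where it says the series, first, only, none or still open, it means among the compounds named here.

For the measured compounds named here, compound 2 `Clc1ccc2[nH]c(SCc3ccccc3C#Cc3ccccc3)nc2c1` gives the higher of the two numbers measured so far in an assay on isolated protein for inhibition of Indoleamine 2,3-dioxygenase 1 (Homo sapiens), with a stated time of 60 min, tested at 10 uM; a lower number here means less inhibition, a higher number more inhibition at the concentration tested (going by the name of the read-out). In this assay compound 2 gives 52%, the highest of the two numbers recorded. Its nearest neighbour is compound 1 `Clc1ccc2[nH]c(SCc3ccccc3Oc3ccccc3)nc2c1`, which in this assay gives 30%. Going by the values given here, the only step measured between them is a number 22 percentage points higher from compound 1 to compound 2 (beyond the scatter), a modest gain that lies beyond the scatter.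

Compound 3 `Clc1ccc2[nH]c(SCc3ccccc3Cc3ccccc3)nc2c1` has not yet been measured. It differs from compound 2 in one place: benzyl in place of 2-phenylethynyl on an aromatic carbon. The benzyl group sits on an aromatic carbon, ortho to a large group, where compound 1 carried phenoxy and compound 2 carried 2-phenylethynyl.

Among the compounds with values here, the single step that bears on this change is a number 22 percentage points higher from compound 1 to compound 2 (beyond the scatter). Benzyl shares its single linking atom with phenoxy rather than with 2-phenylethynyl, so some of that gain is expected to be given back, though not necessarily all of it. The step in this assay is therefore expected to be a number 14 percentage points lower from compound 2 to compound 3 (beyond the scatter), a drop of moderate size. Compound 3 is estimated at 38% in this assay, within a range of 20% to 55%.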

Compound 3, a percentage reported as inhibition, at one concentration (the size of the read-out at that concentration, not a potency): 46%
Compound 3: the middle estimate sits 8 percentage points below what was measured; the measured number falls inside the stated range.
By their numbers in this assay, from the lowest: compound 1; then compounds 3 and 2 (each within the scatter of the next).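

In this assay, the change from 2-phenylethynyl to benzyl gives a number 6 percentage points lower from compound 2 to compound 3 (within the scatter), so at this position, ortho to a large group, the triple bond can be replaced by a benzyl group without a change that can be told from the scatter. The new comparison with phenoxy is more informative: benzyl and phenoxy each join the terminal phenyl ring through a single linking atom, yet the data show a number 16 percentage points higher from compound 1 to compound 3 (beyond the scatter), which separates them and shows that sharing a one-atom link does not by itself place benzyl with phenoxy. Thus, among these three compounds, only the phenoxy compound stands apart, while the benzyl and 2-phenylethynyl compounds remain within the scatter of each other, and nothing available explains this difference.

The compounds shown leave open how a longer chain, such as 2-phenylethyl, would behave at this position. They also leave open whether the terminal phenyl ring is needed at all, a question that a group such as aminomethyl or a carboxylic acid in its place could address.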